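Fluorine scan on the aryl ring of the thiazole acetic acid series

The source may report more compounds than this note shows. Statements on the series, on what has been measured and on what is new or still open speak of the compounds shown alone.

Measured so far in an in vitro functional assay on HEK285-7 cells for antagonist activity at prostaglandin D2 receptor 2 (Homo sapiens), read by BRET and beta-arrestin recruitment; a lower number here means a stronger inhibitor, a higher number a weaker inhibitor:
- compound 1, `O=C(O)Cc1sc(C(c2ccccc2)c2ccccc2)nc1-c1ccccc1`: 370 nM
- compound 2, `O=C(O)Cc1sc(C(c2ccccc2)c2ccccc2)nc1-c1ccc(F)cc1`: 77 nM
- compound 3, `O=C(O)Cc1sc(C(c2ccccc2)c2ccccc2)nc1-c1cccc(F)c1`: 29 nM

Compound 3 gives the lowest number of the three, separated from compound 2 by a 2.7-fold lower number from compound 2 to compound 3 (0.42 log units; beyond the scatter) and from compound 1 by a 13-fold lower number from compound 1 to compound 3 (1.11 log units; beyond the scatter). Compound 4, `O=C(O)Cc1sc(C(c2ccccc2)c2ccccc2)nc1-c1ccc(F)c(F)c1`, carries one further change: fluoro in place of hydrogen on an aromatic carbon, so the 3-fluorophenyl of compound 3 becomes 3,4-difluorophenyl. The step that bears on it is the fluoro-for-hydrogen step at the same position on the ring, a 4.8-fold lower number from compound 1 to compound 2 (0.68 log units; beyond the scatter); that gain may not add in full on top of compound 3. A further decrease in this assay, smaller than that earlier step, is expected. Compound 4 is therefore estimated at 12 nM (range 4 nM to 40 nM). This estimate corresponds to a 2.4-fold lower number from compound 3 to compound 4 (0.38 log units; beyond the scatter).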

Compound 4, half-maximal inhibitory concentration: 43 nM
Compound 4: middle estimate off by 3.6-fold (0.55 log units), on the low side; the whole stated range lies below it.
By their numbers in this assay, from the lowest: compounds 3, 4 and 2 (each within the scatter of the next, the first and the last beyond it); then compound 1.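

In this assay fluoro para to a large group pays only on the unsubstituted phenyl; with the 3-fluorophenyl already present, the step is only a 1.5-fold higher number from compound 3 to compound 4 (0.17 log units; within the scatter) and the change does not transfer: the same change on two cores in this assay, a 4.8-fold lower number (0.68 log units; beyond the scatter) from compound 1 to compound 2 and a 1.5-fold higher number (0.17 log units; within the scatter) from compound 3 to compound 4, 7.1-fold (0.85 log units) apart, beyond the scatter of two such steps
The reverse reading agrees, since the 4-fluorophenyl gives a 1.8-fold lower number from compound 2 to compound 4 (0.25 log units; within the scatter) when the second fluoro enters, against a much larger step on phenyl: the same change on two cores in this assay, a 13-fold lower number (1.11 log units; beyond the scatter) from compound 1 to compound 3 and a 1.8-fold lower number (0.25 log units; within the scatter) from compound 2 to compound 4, 7.1-fold (0.85 log units) apart, beyond the scatter of two such steps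
The 3,4-difluorophenyl still keeps an 8.6-fold lower number from compound 1 to compound 4 (0.93 log units; beyond the scatter) so the two fluoro steps do not add in full, and the gain over phenyl is retained without being extended.

Open, going by these compounds, is whether a nitrile, a methoxy or an amine on this same aromatic carbon would separate from compound 3 and compound 4.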